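The source may hold more compounds than are shown below. What is called first, only, known or untested is meant among the compounds shown, and "the series" means these compounds.

Measured so far in a functional assay on brain (Rattus norvegicus, strain Wistar) for inhibition; on this read-out lower numbers stand for stronger inhibition and higher numbers for weaker inhibition:
- compound 1 `CCCCc1ccc(-c2c(C)[nH]c(=O)n2C)cc1` (10700 nM)
- compound 2 `CCCCCc1ccc(-c2c(C)[nH]c(=O)n2C)cc1` (5900 nM)

Within the data shown here, compound 2 lies within the scatter of compound 1, the only other measured compound, so the two are not separated. Compound 3 `CCCCCCc1ccc(-c2c(C)[nH]c(=O)n2C)cc1` differs from compound 2 by methyl in place of hydrogen on a saturated chain carbon, five bonds along the chain from an aromatic carbon. Among the measured compounds shown here, the one measured step bearing on this is a 1.8-fold lower number from compound 1 to compound 2 (0.26 log units; within the scatter), the same replacement four bonds along the chain from an aromatic carbon. The expected step is similarly small, a 1.5-fold lower number from compound 2 to compound 3 (0.17 log units; within the scatter), with nothing expected beyond the scatter. For compound 3 the estimated value is 4000 nM (expected range 1800 nM to 9000 nM).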

Compound 3, half-maximal inhibitory concentration: 9000 nM
Estimate against measurement, compound 3: 2.3-fold (0.35 log units) below; the range from low to high includes it.
By their numbers in this assay, from the lowest: compounds 2, 3 and 1 (each within the scatter of the next).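

In this assay, methyl at this place, five bonds along the chain from an aromatic carbon, gives a 1.5-fold higher number from compound 2 to compound 3 (0.18 log units; within the scatter), and ethyl in place of hydrogen four bonds along the chain gives a 1.2-fold lower number from compound 1 to compound 3 (0.08 log units; within the scatter). With both steps inside the scatter, compound 1, compound 2 and compound 3 remain unseparated, so this extension of the chain shows no measurable effect here. Nothing available explains these small steps. Open, from the compounds shown here alone, is whether a longer chain, or an amine or a carboxylic acid on this chain, would move the number beyond the scatter.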